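This account rests on a few compounds, and the source may have more. Where it says the series, first, only, none or still open, it means among the compounds named here.

Compound 1 `COc1ccc(F)cc1CNCCCNc1ccnc2cc(C3CCCCC3)ccc12` is the least soluble of the three measured compounds in a physicochemical assay for solubility, with a stated time of 18 h, at pH 7.4 (a lower number here means a less soluble compound, a higher number a more soluble compound), giving 4200 nM. Compound 2 `COc1cccc(CNCCCNc2ccnc3cc(Oc4ccc(F)cc4)ccc23)c1O` gives 14500 nM and compound 3 `Fc1ccc(Oc2ccc3c(NCCCNCc4ccco4)ccnc3c2)cc1` gives 14500 nM, each a step above compound 1 that lies beyond the scatter. For the measured compounds named here, the one measured step, no change at the digits printed from compound 2 to compound 3 (within the scatter), concerns a saturated chain carbon bound to an amine nitrogen and leaves the aromatic carbon untouched. Compound 4 `COc1ccc(F)cc1CNCCCNc1ccnc2cc(-c3cccc4ccccc34)ccc12` differs from compound 1 at that aromatic carbon: naphthalen-1-yl in place of cyclohexyl on an aromatic carbon. Going by the values given here, no measured step bears on this change, so the expected step of a 1.5-fold lower number from compound 1 to compound 4 (0.18 log units; within the scatter) is judged as small, with a modest drop more likely than a rise. Compound 4 is therefore estimated at 2800 nM, with a range from 900 nM to 9000 nM.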

Compound 4, solubility: 32000 nM
Beside the measured number, compound 4's estimate is 11-fold (1.06 log units) below it; the whole stated range lies below it.
By their numbers in this assay, from the lowest: compound 1; then compounds 2 and 3 (each within the scatter of the next); then compound 4.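

In this assay, naphthalen-1-yl in place of cyclohexyl on this aromatic carbon gives a 7.6-fold higher number from compound 1 to compound 4 (0.88 log units; beyond the scatter), so this position responds to the group it carries. For the compounds shown here, the one earlier step, at a saturated chain carbon, showed no change at the digits printed from compound 2 to compound 3 (within the scatter), and neither group exchanged at the aromatic carbon has a hydrogen-bond donor or acceptor. Nothing at hand explains this rise.

As far as these compounds go, whether a single phenyl ring, or an amine such as piperidine, at this carbon would read nearer compound 1 or compound 4 remains open. So does whether naphthalen-2-yl would behave like naphthalen-1-yl.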